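Methoxy added to the hydroxyphenyl partner of compound 3

This account rests on a few compounds, and the source may have more. Where it says the series, first, only, none or still open, it means among the compounds named here.

Compound 1 `COc1ccc(/C=C/c2cc(C)n[nH]2)cc1` and compound 2 `COc1ccc(/C=C/c2cc(C)n[nH]2)cc1OC` share one core; compound 3 `Cc1cc(/C=C/c2ccc(O)cc2)on1` and compound 4 `COc1cc(/C=C/c2cc(C)no2)ccc1O` share another. The difference between the two cores is not broken down here.

In a functional assay on PC-3 cells (Homo sapiens) for cytotoxicity, read by MTT assay, with a stated time of 72 h (a higher number here means a weaker inhibitor, a lower number a stronger inhibitor), compound 1 gives 8900 nM, and compound 2 gives 12600 nM. The change between them is methoxy in place of hydrogen on an aromatic carbon and gives a 1.4-fold higher number from compound 1 to compound 2 (0.15 log units; within the scatter). Compound 3 stands highest of the three measured compounds in this assay, giving 50200 nM; the gap from compound 2 to compound 3 and from compound 1 to compound 3 lies beyond the scatter in both cases.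

Compound 4 carries the same kind of change relative to compound 3: methoxy in place of hydrogen on an aromatic carbon. The surroundings differ, though. In compound 2 the entering methoxy sits ortho to a methoxy group, whereas in compound 4 it sits ortho to a hydroxy group; in both cases it is meta to a group of 8 heavy atoms. Among the compounds with values here, the one measured pair, compound 1 to compound 2, stayed within the scatter, so the same kind of change on compound 3 is expected to do likewise, resting on a 1.4-fold higher number from compound 1 to compound 2 (0.15 log units; within the scatter). The starting point is compound 3 at 50200 nM. Compound 4 is expected to give 58000 nM in this assay, between 25000 nM and 130000 nM, which is an expected step of a 1.2-fold higher number from compound 3 to compound 4 (0.06 log units; within the scatter). Within the data shown here, with only one precedent and a different neighbour at the place, this estimate is held loosely.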

Compound 4, half-maximal inhibitory concentration: 20900 nM
Estimate against measurement, compound 4: 2.8-fold (0.44 log units) above, and the stated range ends above it.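

In this assay, methoxy in place of hydrogen on an aromatic carbon gives a 2.4-fold lower number from compound 3 to compound 4 (0.38 log units; beyond the scatter), a modest step that does not match the earlier one on the core of compound 1, and the two steps differ by more than repeated measurements would explain: the same change on two cores in this assay, a 1.4-fold higher number (0.15 log units; within the scatter) from compound 1 to compound 2 and a 2.4-fold lower number (0.38 log units; beyond the scatter) from compound 3 to compound 4, 3.4-fold (0.53 log units) apart, beyond the scatter of two such steps

In this series, then, the size of this change on one core cannot simply be carried to the other, since a step within the scatter on one core stands beside a step beyond the scatter on the other. This does not show that the core alone sets the outcome: in compound 4 the methoxy is ortho to a hydroxy group, which compound 2 lacks, so the two pairs differ in more than the core, and two pairs support no general rule.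

The compounds shown leave open whether the lower number for compound 4 depends on that hydroxy group, or whether it would also appear on the core of compound 1 with a hydroxy group in the same place. Also open, on these data alone, is whether an amine, a carboxylic acid or a longer chain such as ethoxy at this place would follow methoxy on the core of compound 3.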